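Extending a ring substituent from ethyl to nonyl

A few compounds are considered here, and "the series" means these few. Any claim that something is new, unique, unknown or untested is made for them only; others in the source may bear on it.

Measured so far:
compound 1 `C=C1C(=O)N(c2ccccc2)N(C)C1c1ccccc1`, 40900 nM
compound 2 `C=C1CN(C)N(c2ccccc2)C1=O`, 45700 nM
compound 3 `C=C1C(=O)N(c2ccccc2)N(C)C1CC`, 750000 nM

Compound 3 has the highest number of the three in a functional assay on HL-60 cells (Homo sapiens) for inhibition, read by MTT assay, with a stated time of 48 h; a higher number here means a weaker inhibitor, a lower number a stronger inhibitor: its steps to both neighbours, a 16-fold higher number from compound 2 to compound 3 (1.22 log units; beyond the scatter) and an 18-fold higher number from compound 1 to compound 3 (1.26 log units; beyond the scatter), lie beyond the scatter. Compound 4 `C=C1C(=O)N(c2ccccc2)N(C)C1CCCCCCCCC` differs from compound 3 by heptyl in place of hydrogen on a saturated chain carbon, two bonds along the chain from a saturated ring carbon. Among the compounds with values here, none of the measured steps lengthens a chain; the two that reach compound 3 swap a ring substituent entirely, so they bear only loosely on this change. Within the data shown here, with no guiding step, compound 4 is expected to stay close to compound 3, the change a 1.5-fold lower number from compound 3 to compound 4 (0.18 log units; within the scatter) carrying wide uncertainty. Compound 4 is estimated at 500000 nM, within 100000 nM to 2500000 nM.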

Compound 4, half-maximal inhibitory concentration: 49900 nM
For compound 4 the middle estimate is 10-fold (1.00 log units) above the measured one; the measured number lies below the stated range.
By their numbers in this assay, from the lowest: compounds 1, 2 and 4 (each within the scatter of the next); then compound 3.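

Chain length alone moves the number at this position: in this assay, heptyl in place of hydrogen on a saturated chain carbon, two bonds along the chain from a saturated ring carbon, gives a 15-fold lower number from compound 3 to compound 4 (1.18 log units; beyond the scatter) for a change that leaves the ring substituent's point of attachment the same. Compounds 1, 2 and 4 now sit together, each within the scatter of the next, and compound 3 stands alone. No measurement shown here explains this step.

From the compounds shown here alone, whether the number falls gradually or abruptly across the chains between ethyl and nonyl remains open. So does the effect of a longer chain such as dodecyl, or of a chain carrying an amine.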